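The compounds below may be only part of what the source reports. "The series", "measured", "known", "first", "only" and "open" are said of these compounds alone.

Compound 1 `COc1ccc(C(=O)/C=C/c2cc3cc(C)ccc3nc2Cl)cc1` and compound 2 `O=C(/C=C/c1cnc2ccccc2c1)C1CC1` were both examined in an assay on cell membranes for displacement of a labelled ligand from metabotropic glutamate receptor 5 (Rattus norvegicus), read by scintillation counting, with a stated time of 60 min; on this read-out higher numbers stand for weaker inhibition and lower numbers for stronger inhibition. In this assay compound 1 gives > 100000 nM, which is a limit of the assay rather than a measured number. Compound 2 likewise gives > 100000 nM, again only a limit. Compound 1 therefore stands at the edge of what the assay can report, and so does every other value shown (the limit of > 100000 nM in this assay, at which 2 of the 2 values shown sit).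

Compound 3 `Cc1ccc2nc(Cl)c(/C=C/C(=O)c3ccccc3)cc2c1` has not yet been tested. It differs from compound 1 in one place: hydrogen in place of methoxy on an aromatic carbon. Among the compounds with values here, no pair of measured compounds differing in a single place is available, so no measured step can guide the expectation. With compound 1 already at a limit, the step from compound 1 to compound 3 is expected to be a number no higher from compound 1 to compound 3 (the limit leaves the size open), none beyond the scatter. Compound 3 is thus estimated at 100000 nM, with a range from 20000 nM to 300000 nM.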

Compound 3, inhibition constant: > 100000 nM
Compound 3: no number, only a limit (the forecaster's own chance of this, stated with the estimate: 80%); the middle value sits exactly at the limit.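

No step can be read from compound 1 to compound 3, since neither compound gives a number in this assay and both stand only at a limit: the limit of > 100000 nM in this assay, at which 3 of the 3 values shown sit.

The compounds shown leave open whether hydrogen in place of methoxy changes binding at all, and what change would bring a readable number.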